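Acetylation of a hydroxy group and cytotoxicity in lymphocytes

This account rests on a few compounds, and the source may have more. Where it says the series, first, only, none or still open, it means among the compounds named here.

Measured compounds:
compound 1 `COc1ccc(C(=O)O[C@H]2CC(C)=C[C@H](O)[C@@]3(C)[C@@H](OC(C)=O)C[C@@](O)(C(C)C)[C@H]23)cc1` with 27200 nM
compound 2 `COc1ccc(C(=O)O[C@H]2CC(C)=C[C@H](OC(C)=O)[C@]3(C)[C@@H]2[C@](O)(C(C)C)C[C@@H]3O)cc1` with 33700 nM

Of the compounds shown here, two have been measured in an ADME assay on PBL cells (Homo sapiens) for cytotoxicity, read by MTT assay, with a stated time of 72 h; on this read-out higher numbers stand for weaker inhibition and lower numbers for stronger inhibition. Compound 1 gives 27200 nM in this assay, and compound 2 gives 33700 nM. Compound 2 holds the highest of the two numbers, but its nearest neighbour, compound 1, lies within the scatter of it, so the two values show no difference that can be read as a real one.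

Compound 3 `COc1ccc(C(=O)O[C@H]2CC(C)=C[C@H](OC(C)=O)[C@@]3(C)[C@@H](OC(C)=O)C[C@@](O)(C(C)C)[C@H]23)cc1` has not yet been measured. It differs from compound 2 in one place: acetyl in place of hydrogen on an oxygen on a saturated carbon. Cut one bond further out, the same change reads hydroxy to acetoxy.

Going by the values given here, no pair of measured compounds differing in a single place is available, so the size of such a step in this assay is not known from these data. Among the compounds with values here, with only two values, both within the scatter of each other, the expectation for compound 3 is a step of no more than the scatter, in no particular direction, a 1.1-fold lower number from compound 2 to compound 3 (0.05 log units; within the scatter). On that basis compound 3 is estimated at 30000 nM, with a range from 12000 nM to 75000 nM.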

Compound 3, half-maximal inhibitory concentration: 9400 nM
Beside the measured number, compound 3's estimate is 3.2-fold (0.50 log units) above it, and the stated range ends above it.
By their numbers in this assay, from the lowest: compound 3; then compounds 1 and 2 (each within the scatter of the next).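

In this assay, hydroxy to acetoxy gives a 3.6-fold lower number from compound 2 to compound 3 (0.55 log units; beyond the scatter), and the same change at a different hydroxy group of the shared core gives a 2.9-fold lower number from compound 1 to compound 3 (0.46 log units; beyond the scatter). Going by these compounds alone, these are the first steps that can be read as real: both run in the same direction and lie beyond the scatter, so a second acetyl group on the core goes with a lower number, meaning stronger inhibition, from either of the compounds carrying only one, and compound 3, with acetoxy at both places, stands lowest of the three. The data offer nothing that accounts for this drop in the number.

As far as these compounds go, what stays open is whether the step belongs to the acetyl group itself or would also appear with a longer acyl chain such as butanoyl, with a benzoyl group, or with a simple methyl ether on the same oxygen. Also open, from the compounds shown here alone, is how the hydroxy group that remains free in compound 3 would behave under the same change, and whether the step would hold in any cells other than these.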